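One benzyl group exchanged on a shared core

The source may hold more compounds than are shown below. What is called first, only, known or untested is meant among the compounds shown, and "the series" means these compounds.

Compound 1 `CCOc1ccc(OC(F)(F)F)cc1Cn1c(C(=O)NCC(C)(C)CO)cc2cc(C#N)ccc21` gives 20 mL.min-1.g-1
Compound 2 `CC(C)(CO)CNC(=O)c1cc2cc(C#N)ccc2n1Cc1cc(Cl)cc(Cl)c1` gives 22 mL.min-1.g-1

Going by the values given here, in an in vitro ADME assay on microsomes from liver (Homo sapiens) for metabolic stability, in the presence of a further agent that is not named here (a higher number here means faster removal of the compound, a lower number slower removal), compound 2 gives 22 mL.min-1.g-1 and compound 1 gives 20 mL.min-1.g-1 with no separation beyond the scatter, so compound 2 stands level with the only other measured compound. Compound 3 `COc1ccc(Br)cc1Cn1c(C(=O)NCC(C)(C)CO)cc2cc(C#N)ccc21` has not yet been measured. Its structural change is 5-bromo-2-methoxyphenyl in place of 3,5-dichlorophenyl on a saturated chain carbon bound to an aromatic nitrogen (5-bromo-2-methoxyphenyl in place of 3,5-dichlorophenyl). Among the compounds with values here, no measured pair isolates such an exchange. Compound 1 (20 mL.min-1.g-1) and compound 2 (22 mL.min-1.g-1) carry different substituted benzyl groups on the shared core, yet their values stay within the scatter. The expected step of a 1.1-fold lower number from compound 2 to compound 3 (0.04 log units; within the scatter) is therefore none beyond the scatter, in either direction. In this assay the estimate for compound 3 is 20 mL.min-1.g-1 with an expected range (9 mL.min-1.g-1 to 42 mL.min-1.g-1).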

Compound 3, intrinsic clearance in microsomes: 23 mL.min-1.g-1
Estimate against measurement, compound 3: 1.2-fold (0.06 log units) below; the range from low to high includes it.
By their numbers in this assay, from the lowest: compounds 1, 2 and 3 (each within the scatter of the next).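

In this assay, the exchange of 3,5-dichlorobenzyl for 5-bromo-2-methoxybenzyl gives a 1.0-fold higher number from compound 2 to compound 3 (0.02 log units; within the scatter). Going by these compounds alone, this is the first direct reading of a single change at this position, on a saturated chain carbon bound to an aromatic nitrogen, and it shows that this exchange leaves the clearance level, even though two chlorine atoms give way to one bromine atom and a methoxy group, and the entering group carries a hydrogen-bond acceptor that the leaving group lacks. No measured evidence bears on why the number holds level. All the compounds shown keep a substituted phenyl ring at this position, so the reading covers only such groups. From the compounds shown here alone, whether an amine or a carboxylic acid on that ring would separate from these values beyond the scatter remains open.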